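The compounds below may be only part of what the source reports. "The series", "measured", "known", "first", "only" and "open" are said of these compounds alone.

Measured in an ADME assay on J774.A1 cells (Mus musculus) for cytotoxicity, read by MTT assay, with a stated time of 72 h; on this read-out lower numbers stand for stronger inhibition and higher numbers for weaker inhibition:
compound 1 `CCOC(=O)c1c(C)[n+]([O-])c2cc(-n3cncn3)c(F)cc2[n+]1[O-]` gives 77700 nM
compound 2 `Cc1c(C(=O)OC(C)C)[n+]([O-])c2cc(F)c(-n3ccnc3)cc2[n+]1[O-]` gives 77700 nM

Compound 1 (77700 nM) stands level with compound 2 at the digits reported. Going by the values given here, the two differ in more than one place, so the series offers no measured single-change step.

Compound 3 `Cc1c(C(=O)OCc2ccccc2)[n+]([O-])c2cc(F)c(-n3cncn3)cc2[n+]1[O-]` departs from compound 1 by one change (phenyl in place of methyl on a saturated chain carbon bound to an oxygen next to a carbonyl group): phenyl in place of methyl on a saturated chain carbon bound to an oxygen next to a carbonyl group, which also reads as ethyl to benzyl.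

Among the compounds with values here, with no measured step to go on, the expectation in this assay rests on the level of compound 1 (77700 nM) alone. A small move toward stronger inhibition, not beyond the scatter, is expected (a 1.4-fold lower number from compound 1 to compound 3 (0.15 log units; within the scatter)). The estimated value for compound 3 is 55000 nM (expected range 20000 nM to 110000 nM).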

Compound 3, half-maximal inhibitory concentration: 77700 nM
The estimate for compound 3 lay 1.4-fold (0.15 log units) below the measured number, within the range that was stated.
By their numbers in this assay, from the lowest: compounds 1, 2 and 3 (each within the scatter of the next).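

In this assay, going by these compounds alone, phenyl in place of methyl on a saturated chain carbon bound to an oxygen next to a carbonyl group gives the first single-change reading of the series (no change at the digits printed from compound 1 to compound 3 (within the scatter)). The same difference reads as ethoxy to benzyloxy, so this position accepts the entry of one six-membered aromatic ring of carbon only, with no step beyond the scatter in this read-out. Nothing available accounts for this flat reading.

From the compounds shown here alone, whether an amine or a carboxylic acid on this chain carbon, or a longer chain ending in phenyl, would read the same stays open. Also open, going by these compounds, is whether ethyl to benzyl gives the same reading on the core of compound 2, since one step at one position says nothing about other cores.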